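The source may report more compounds than this note shows. Statements on the series, on what has been measured and on what is new or still open speak of the compounds shown alone.

Three compounds share one core and differ only in the group attached to one aromatic carbon of that core. Compound 1 `Cc1n[nH]c2ncc(C#Cc3c(F)ccc(NS(=O)(=O)c4cccnc4)c3F)cc12` carries a methyl there, and in a functional assay on HCT-116 cells (Homo sapiens) for antiproliferative activity, read by MTT assay, with a stated time of 68 h (on this read-out lower numbers stand for stronger inhibition and higher numbers for weaker inhibition), compound 1 gives 4630 nM. Compound 2 `O=S(=O)(Nc1ccc(F)c(C#Cc2cnc3[nH]nc(C4CC4)c3c2)c1F)c1cccnc1` carries a cyclopropyl in its place, and in this assay compound 2 gives 584 nM. Compound 3 `O=S(=O)(Nc1ccc(F)c(C#Cc2cnc3[nH]nc(-c4ccccc4)c3c2)c1F)c1cccnc1` carries a phenyl, and in this assay compound 3 reaches only the limit of the assay, > 10000 nM, not a number. Within this set the cyclopropyl change brought a 7.9-fold lower number from compound 1 to compound 2 (0.90 log units; beyond the scatter), the phenyl change brought an at least 2.1-fold higher number from compound 1 to compound 3 (0.33 log units; beyond the scatter), and between the two larger groups the difference was an at least 17-fold higher number from compound 2 to compound 3 (1.23 log units; beyond the scatter). Compound 3 thus stands at the weak end, known only as a limit (the limit of > 10000 nM in this assay, at which 1 of the 3 values shown sits).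

Compound 4 `O=S(=O)(Nc1ccc(F)c(C#Cc2cnc3[nH]nc(-c4ccccc4Cl)c3c2)c1F)c1cccnc1` differs from compound 3 by chloro in place of hydrogen on an aromatic carbon. For the measured compounds named here, no measured step touches a substituent on the phenyl itself; the only related steps are those leading to phenyl, all of which pointed toward weaker inhibition. The step from compound 3 to compound 4 is therefore expected to be small, a step that the limit leaves unreadable from compound 3 to compound 4, with no clear direction beyond the scatter. Compound 4 is expected to give about 15000 nM in this assay, within a range of 4000 nM to 50000 nM, and quite possibly again only a limit.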

Compound 4, half-maximal inhibitory concentration: > 10000 nM
Compound 4: a limit, no number; the forecaster's own chance of this, stated with the estimate: 60%; the middle value is on the limit's open side.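

In this assay compound 4 gives > 10000 nM, a limit and not a number, and with limits on both sides the step from compound 3 to compound 4 cannot be read. Measured against the two smaller groups, 2-chlorophenyl gives an at least 17-fold higher number from compound 2 to compound 4 (1.23 log units; beyond the scatter) and an at least 2.1-fold higher number from compound 1 to compound 4 (0.33 log units; beyond the scatter), so adding a chloro to the phenyl did not lift the compound out of the weak end of this set. What is new is that this weak end at the position now holds a substituted phenyl as well as the bare one: the limit of > 10000 nM in this assay, at which 2 of the 4 values shown sit.

From the compounds shown here alone, how far compound 3 and compound 4 really lie from each other stays unknown, and so does whether the chloro has any effect at all in this assay. Going by these compounds, it also remains open whether a different group on the phenyl, such as a methoxy or an amine, would give a real number, and whether an ethyl or a cyclobutyl at this position would match or pass the cyclopropyl of compound 2.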